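From 2,6-difluorophenyl to 3,5-difluorophenyl

The compounds below may be only part of what the source reports. "The series", "measured", "known", "first", "only" and "open" are said of these compounds alone.

In a functional assay on the whole organism for inhibition, with Lemna aequinoctialis as the target, with a stated time of 7 days, tested at 50 ug/mL (on this read-out lower numbers stand for less inhibition of growth and higher numbers for more inhibition of growth at the one concentration tested), compound 1 (`O=C1Nc2ccc(F)cc2/C1=N/NC(=S)Nc1ccccc1F`) gives 25%, compound 2 (`O=C1Nc2ccc(F)cc2/C1=N/NC(=S)Nc1ccc(F)cc1F`) gives 20% and compound 3 (`O=C1Nc2ccc(F)cc2/C1=N/NC(=S)Nc1c(F)cccc1F`) gives 10%. Compound 3 is separated from only one of the others by more than the scatter: the data show a number 15 percentage points lower from compound 1 to compound 3 (beyond the scatter), but a number 10 percentage points lower from compound 2 to compound 3 (within the scatter). Compound 4 (`O=C1Nc2ccc(F)cc2/C1=N/NC(=S)Nc1cc(F)cc(F)c1`) differs from compound 3 as follows: 3,5-difluorophenyl in place of 2,6-difluorophenyl on an amide-type nitrogen. Within the data shown here, the closest precedent is the other swap of one difluorophenyl group for another, a number 10 percentage points lower from compound 2 to compound 3 (within the scatter), while adding a fluoro gave a number 5 percentage points lower from compound 1 to compound 2 (within the scatter). Among the measured compounds shown here, no measured compound carries the 3,5-difluorophenyl group, so only a small upward move is expected, toward the other two values. The expected step is a number 8 percentage points higher from compound 3 to compound 4 (within the scatter). For compound 4 the estimated value is 18%, with an expected range of 5% to 35%.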

Compound 4, percent growth inhibition at one concentration: 10%
Estimate against measurement, compound 4: 8 percentage points above; low and high end bracket the measured number.
By their numbers in this assay, from the lowest: compounds 3, 4, 2 and 1 (each within the scatter of the next, the first and the last beyond it).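

In this assay, 3,5-difluorophenyl in place of 2,6-difluorophenyl on the amide-type nitrogen gives no change at the digits printed from compound 3 to compound 4 (within the scatter), so this rearrangement of the two fluoro groups leaves the number where it stood. The new group also shows a number 15 percentage points lower from compound 1 to compound 4 (beyond the scatter) against 2-fluorophenyl, and a number 10 percentage points lower from compound 2 to compound 4 (within the scatter) against 2,4-difluorophenyl, the same two steps that the 2,6-difluorophenyl group shows. Nothing available explains these numbers. On these data alone, every group at this place is a fluorophenyl, so the effect of a chloro, methoxy, amine or carboxylic acid substituent on the phenyl ring stays open. Whether any of these compounds differ at other concentrations also stays open.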